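The source may hold more compounds than are shown below. What is called first, only, known or untested is meant among the compounds shown, and "the series" means these compounds.

In a functional assay on CCRF-CEM cells (Homo sapiens), read by MTT assay, with a stated time of 72 h (on this read-out lower numbers stand for stronger inhibition and higher numbers for weaker inhibition), compound 1 `CNc1ncnc2c1c(-c1ccsc1)cn2[C@@H]1O[C@H](CO)[C@@H](O)[C@H]1O` gives only a limit of the assay, > 20000 nM. The two measured neighbours alter a different place of the shared core. Among the compounds with values here, compound 2 `COc1ncnc2c1c(-c1ccsc1)cn2[C@@H]1O[C@H](CO)[C@@H](O)[C@H]1O` gives 2570 nM, and the step of an at least 7.7-fold lower number from compound 1 to compound 2 (0.89 log units; beyond the scatter) is the one readable change. Compound 3 `CSc1ncnc2c1c(-c1ccsc1)cn2[C@@H]1O[C@H](CO)[C@@H](O)[C@H]1O` again sits at a limit, > 20000 nM. The step of an at least 7.7-fold higher number from compound 2 to compound 3 (0.89 log units; beyond the scatter) runs the other way, while the step that the two limits leave unreadable from compound 1 to compound 3 cannot be read because of the limit of > 20000 nM in this assay, at which 2 of the 3 values shown sit. Compound 4 `CNc1ncnc2c1c(I)cn2[C@@H]1O[C@H](CO)[C@@H](O)[C@H]1O` differs from compound 1 at another place: iodo in place of thiophen-3-yl on an aromatic carbon. Within the data shown here, no measured step touches that place, so its size and direction cannot be drawn from these three compounds. Compound 4 is therefore expected near 15000 nM, between 3000 nM and 60000 nM, a step of an at least 1.3-fold lower number from compound 1 to compound 4 (0.12 log units; that floor lies within the scatter).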

Compound 4, half-maximal inhibitory concentration: > 100000 nM
Compound 4 ended at the assay's limit; the forecaster's own chance of this, stated with the estimate: 60%; at least 6.6-fold (0.82 log units) between middle value and limit.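

Compound 4 sits at a limit: the limit of > 100000 nM in this assay, at which 1 of the 4 values shown sits. Within the data shown here, compound 1 also sits at a limit, so no step between the two can be read: the limit of > 20000 nM in this assay, at which 2 of the 4 values shown sit. The compounds shown leave open how iodo compares with thiophen-3-yl at this place on the shared core.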